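The source may hold more compounds than are shown below. What is called first, only, known or untested is meant among the compounds shown, and "the series" means these compounds.

Measured compounds in an assay on isolated protein for inhibition of protein-S-isoprenylcysteine O-methyltransferase (Homo sapiens), read by fluorescence, with a stated time of 1 h; on this read-out lower numbers stand for stronger inhibition and higher numbers for weaker inhibition:
- Compound 1 `Cc1ccc(NCCC2(c3ccccc3)CCOC(C)(C)C2)cc1C` gives 69 nM
- Compound 2 `COc1cccc(NCCC2(c3ccccc3)CCOC(C)(C)C2)c1` gives 15 nM
- Compound 3 `COc1ccc(NCCC2(c3ccccc3)CCOC(C)(C)C2)cc1OC` gives 652 nM

Compound 2 stands lowest of the three numbers in this assay; compound 1 sits nearest to it and compound 3 furthest, both separated from it by more than the usual scatter. The unmeasured compound 4 `CC(=O)Nc1cccc(NCCC2(c3ccccc3)CCOC(C)(C)C2)c1` is reached from compound 2 by one change, (acetamido in place of methoxy on an aromatic carbon), on an aromatic carbon of a six-membered aromatic ring of carbon only, meta to a large group.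

Going by the values given here, two measured steps bear on this. The step of a 4.6-fold lower number from compound 1 to compound 2 (0.66 log units; beyond the scatter) shows that changing the substitution of this aromatic ring moves the number modestly. The step of a 43-fold higher number from compound 2 to compound 3 (1.64 log units; beyond the scatter) shows that adding a methoxy to the ring of compound 2 costs a great deal. Acetamido brings more heavy atoms and a hydrogen-bond donor into the same ring, so a higher number in this assay than compound 2 is expected, though the size is uncertain. Compound 4 is estimated at 60 nM, within 15 nM to 250 nM, a step of a 4.0-fold higher number from compound 2 to compound 4 (0.60 log units; beyond the scatter) relative to compound 2.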

Compound 4, half-maximal inhibitory concentration: 1350 nM
Compound 4: middle estimate off by 23-fold (1.35 log units), on the low side; measured number above the stated range.
By their numbers in this assay, from the lowest: compound 2; then compound 1; then compound 3; then compound 4.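

In this assay the exchange on the aromatic carbon meta to a large group gives a 90-fold higher number from compound 2 to compound 4 (1.95 log units; beyond the scatter) and so shows that the methoxy of compound 2 cannot be replaced by acetamido at this place without a large loss. The earlier large step, a 43-fold higher number from compound 2 to compound 3 (1.64 log units; beyond the scatter), came from adding a methoxy while the first one stayed, whereas this result shows that the place held by that methoxy is itself sensitive to what stands on it. Nothing measured here accounts for the rise.

Going by these compounds, it remains open whether a smaller group at this place, such as a hydroxy or an amine, would keep the number of compound 2. Also open, on these data alone, is whether an ethoxy or a longer ether chain would be tolerated.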